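The compounds below may be only part of what the source reports. "The series", "measured", "known", "first", "only" and "open" are said of these compounds alone.

Measured so far in a functional assay on SGC-7901 cells (Homo sapiens) for inhibition, read by MTT assay, with a stated time of 24 h; on this read-out lower numbers stand for stronger inhibition and higher numbers for weaker inhibition:
Compound 1 `CC1(C)[C@H]2CC[C@]1(C)N(Cc1cn(-c3cccc(F)c3)nn1)C(=O)C2` gives 530 nM
Compound 2 `CC1(C)[C@H]2CC[C@]1(C)N(Cc1cn(-c3cccc(C#N)c3)nn1)C(=O)C2` gives 250 nM

Compound 2 at 250 nM holds the lower of the two numbers and so shows the stronger inhibition. Compound 3 `CC1(C)[C@H]2CC[C@]1(C)N(Cc1cn(-c3cccc(Cl)c3)nn1)C(=O)C2` keeps the shared core and changes one group: chloro in place of cyano on an aromatic carbon. Among the measured compounds shown here, one measured step bears on this change, the exchange of fluoro for cyano (a 2.1-fold lower number from compound 1 to compound 2 (0.33 log units; beyond the scatter)), which was modest and beyond the scatter. For the measured compounds named here, no chloro compound has been measured, so that step suggests a likely size but settles no direction. Going by the values given here, compound 3 gives up the cyano group of compound 2, and the only measured compound without that group, compound 1 at 530 nM, has the higher number. A small move toward a higher number in this assay is therefore expected, probably no larger than the measured step. The expected change is small (a 1.7-fold higher number from compound 2 to compound 3 (0.23 log units; within the scatter)). The estimate for compound 3 is 420 nM with an expected range from 180 nM to 950 nM in this measurement.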

Compound 3, half-maximal inhibitory concentration: 510 nM
For compound 3 the middle estimate is 1.2-fold (0.08 log units) below the measured one; low and high end bracket the measured number.
By their numbers in this assay, from the lowest: compound 2; then compounds 3 and 1 (each within the scatter of the next).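

With chloro on this aromatic carbon, the exchange for cyano gives a 2.0-fold higher number from compound 2 to compound 3 (0.31 log units; beyond the scatter), so the lower number of compound 2 now stands against two halogen-bearing compounds rather than against a single fluoro compound. The exchange of fluoro for chloro gives a 1.0-fold lower number from compound 1 to compound 3 (0.02 log units; within the scatter), which means that this assay does not separate these two halogens at this position, while the step of a 2.1-fold lower number from compound 1 to compound 2 (0.33 log units; beyond the scatter) is about the same size as the new step from cyano to chloro, so among these three groups only the cyano group marks a difference. No measurement at hand explains why the cyano compound differs from the two halogen compounds here.

The three compounds leave open whether the lower number belongs to the nitrile alone or would also appear with other groups on the same aromatic carbon, such as an amine, a carboxylic acid, a methoxy group or a longer alkyl chain. They also leave open whether the exchange of cyano for chloro would give a step of similar size on another carbon of this six-membered aromatic ring or with a different shared core.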